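Methoxy to Ethoxy on the Vinyl Compound

This account rests on a few compounds, and the source may have more. Where it says the series, first, only, none or still open, it means among the compounds named here.

In a functional assay on HT-29 cells (Homo sapiens) for inhibition, read by sulforhodamine B assay, with a stated time of 72 h (on this read-out lower numbers stand for stronger inhibition and higher numbers for weaker inhibition), compound 3 `C=CC1C(=O)N(c2cc(OC)c(OC)c(OC)c2)C1c1ccc(OC)cc1` gives 10 nM, the lowest of three numbers, against compound 2 `COc1ccc(C2C(Oc3ccccc3)C(=O)N2c2cc(OC)c(OC)c(OC)c2)cc1` at 52 nM and compound 1 `CCOc1ccc(C2C(C3CC3)C(=O)N2c2cc(OC)c(OC)c(OC)c2)cc1` at 63 nM. Compound 4 `C=CC1C(=O)N(c2cc(OC)c(OC)c(OC)c2)C1c1ccc(OCC)cc1` turns methoxy into ethoxy: methyl in place of hydrogen on a saturated chain carbon bound to an oxygen on an aromatic ring. Among the compounds with values here, no measured step covers this change. The only one, a 5.2-fold lower number from compound 2 to compound 3 (0.72 log units; beyond the scatter), puts vinyl in place of phenoxy and bears on it only indirectly. Compound 1 carries 4-ethoxyphenyl but also differs elsewhere. A small shift towards a higher number in this assay is expected, an estimated 1.5-fold higher number from compound 3 to compound 4 (0.18 log units; within the scatter), within the scatter. Compound 4 is estimated at 15 nM, with an expected range of 5 nM to 45 nM.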

Compound 4, half-maximal inhibitory concentration: 97 nM
Compound 4: middle estimate off by 6.5-fold (0.81 log units), on the low side, outside the stated range (above it).
By their numbers in this assay, from the lowest: compound 3; then compounds 2, 1 and 4 (each within the scatter of the next).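

In this assay, the change from 4-methoxyphenyl to 4-ethoxyphenyl on the vinyl compound is not silent: one methyl added on a saturated chain carbon bound to an oxygen on an aromatic ring gives a 9.7-fold higher number from compound 3 to compound 4 (0.99 log units; beyond the scatter). With 4-ethoxyphenyl held fixed, vinyl in place of cyclopropyl gives a 1.5-fold higher number from compound 1 to compound 4 (0.19 log units; within the scatter), so the two groups cannot be told apart here. Nothing at hand explains the rise seen with the added methyl. Going by these compounds, whether a propoxy group or a longer chain would raise the number further, and how a hydroxyl would read in this place, stays open.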